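Cyano for bromo in a p300 histone acetyltransferase series

The source may hold more compounds than are shown below. What is called first, only, known or untested is meant among the compounds shown, and "the series" means these compounds.

Compound 1 `Brc1ccc(-c2ncc(OCC3CCNCC3)nc2-c2ccc(Br)cc2)cc1` stands highest of the three measured compounds in an assay on isolated protein for inhibition of histone acetyltransferase p300 (Homo sapiens), read by scintillation counting, with stated times of 10 min and 30 min, tested at 10 uM (a higher number here means more inhibition at the concentration tested (going by the name of the read-out), a lower number less inhibition), where compound 1 gives 72.5%. Compound 2 `Brc1ccc(-c2ncc(OCC3CCNC3)nc2-c2ccc(Br)cc2)cc1` gives 42.7%, and the change between them was a number 29.8 percentage points lower from compound 1 to compound 2 (beyond the scatter). Compound 3 `Brc1ccc(-c2ncc(OCC3CCNCC3)nc2-c2ccc(Br)c(Br)c2)cc1Br` gives 50%. Compound 4 `N#Cc1ccc(-c2nc(OCC3CCNCC3)cnc2-c2ccc(Br)cc2)cc1` differs from compound 1 by cyano in place of bromo on an aromatic carbon. Neither measured step concerns this change: the step to compound 2 alters the saturated chain, and compound 3 carries additional bromo groups. With nothing that bears directly on it, the expectation is a small step, a number 12.5 percentage points lower from compound 1 to compound 4 (beyond the scatter), possibly none beyond the scatter. Compound 4 is therefore estimated at 60%, with a range from 30% to 85%.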

Compound 4, a percentage reported as inhibition, at one concentration (the size of the read-out at that concentration, not a potency): 21%
For compound 4 the middle estimate is 39 percentage points above the measured one; the whole stated range lies above it.
By their numbers in this assay, from the lowest: compound 4; then compounds 2 and 3 (each within the scatter of the next); then compound 1.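

In this assay, the replacement of 4-bromophenyl by 4-cyanophenyl gives a number 51.5 percentage points lower from compound 1 to compound 4 (beyond the scatter), a large step. Among these compounds, compounds 2 and 3 keep bromo at this place, so only this pair shows that inhibition at the concentration tested depends on the group on this aromatic carbon. Nothing available accounts for the step. The compounds shown leave open how chloro, methyl or methoxy would fare at this place, and whether any of them would stand nearer to compound 1 than cyano does. They also leave open what the same change would do at the remaining bromo.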